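Trifluoromethoxy for trifluoromethyl on compound 3

A few compounds are considered here, and "the series" means these few. Any claim that something is new, unique, unknown or untested is made for them only; others in the source may bear on it.

Values in a functional assay on A549 cells (Homo sapiens) for cytotoxicity, read by MTT assay, with a stated time of 72 h; a lower number here means a stronger inhibitor, a higher number a weaker inhibitor:
- compound 1 `CNC(=O)c1cc(Oc2ccc(NC(=O)c3nn(-c4ccccc4C(F)(F)F)c(=O)cc3C)cc2F)ccn1`: > 40000 nM (a limit of the assay, not a number)
- compound 2 `Cc1cc(=O)n(-c2ccccc2C(F)(F)F)nc1C(=O)Nc1ccc(Oc2ncnc3ccsc23)cc1`: 8850 nM
- compound 3 `Cc1cc(=O)n(-c2ccccc2C(F)(F)F)nc1C(=O)Nc1ccc(Oc2ncnc3ccsc23)c(F)c1`: 4680 nM

Compound 3 has a measured value of 4680 nM and shares its place with compound 2, since a 1.9-fold lower number from compound 2 to compound 3 (0.28 log units; within the scatter) lies within the scatter. The comparison with the limit compound is wider, at an at least 8.5-fold lower number from compound 1 to compound 3 (0.93 log units; beyond the scatter), which lies beyond the scatter.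

The next structure is compound 4 `Cc1cc(=O)n(-c2ccccc2OC(F)(F)F)nc1C(=O)Nc1ccc(Oc2ncnc3ccsc23)c(F)c1`, which carries trifluoromethoxy in place of trifluoromethyl on an aromatic carbon, ortho to a large group (trifluoromethoxy in place of trifluoromethyl on an aromatic carbon). Among the measured compounds shown here, no measured step changes this group. The fluoro step, a 1.9-fold lower number from compound 2 to compound 3 (0.28 log units; within the scatter), and the exchange of the group on the oxygen, an at least 8.5-fold lower number from compound 1 to compound 3 (0.93 log units; beyond the scatter), both lie elsewhere in the structure, and neither gives a size or direction for this change. With no measured guide, no shift beyond the scatter is expected in this assay. The expected step is a 1.0-fold lower number from compound 3 to compound 4 (0.02 log units; within the scatter). For compound 4 the estimated value is 4500 nM, with an expected range from 1800 nM to 12000 nM.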

Compound 4, half-maximal inhibitory concentration: 5720 nM
Beside the measured number, compound 4's estimate is 1.3-fold (0.10 log units) below it; measured number inside the range.
By their numbers in this assay, from the lowest: compounds 3, 4 and 2 (each within the scatter of the next). At a limit, above all of these: compound 1.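

In this assay, the exchange on the 2-(trifluoromethyl)phenyl group gives a 1.2-fold higher number from compound 3 to compound 4 (0.09 log units; within the scatter), so trifluoromethoxy in place of trifluoromethyl on this aromatic carbon, ortho to a large group, leaves the number within the scatter. Among the compounds shown here, the earlier steps all lie elsewhere in the structure, which makes this the only reading of this position, and it covers a single exchange on a single core. No measurement shown bears on the reason for this result.

Going by these compounds, an amine, a carboxylic acid or a nitrile at this place remains open, as does whether any such group would move the number beyond the scatter. Also open, on these data alone, is whether the same exchange reads alike on the core of compound 2, which lacks the fluoro.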